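The source may hold more compounds than are shown below. What is called first, only, known or untested is meant among the compounds shown, and "the series" means these compounds.

Compound 1 `Fc1ccc2nc(-c3cncnc3)n(C3CC3)c2c1` gives 5380 nM in an ADME assay on cells for inhibition of cytochrome P450 11B1, mitochondrial (Homo sapiens), read by HPLC, with a stated time of 60 min; on this read-out higher numbers stand for weaker inhibition and lower numbers for stronger inhibition. Compound 2 `Fc1cc2nc(-c3cncnc3C3CC3)n(C3CC3)c2cc1F` returns only a limit in this assay, > 10000 nM. Of the two values shown, compound 2 sits at the limit of > 10000 nM in this assay, at which 1 of the 2 values shown sits, so its exact standing is not known. Compound 3 `Fc1cc2nc(-c3cncnc3NCCC(F)(F)F)n(C3CC3)c2cc1F` differs from compound 2 by (3,3,3-trifluoropropyl)amino in place of cyclopropyl on an aromatic carbon, in words (3,3,3-trifluoropropyl)amino in place of cyclopropyl on an aromatic carbon. With compound 2 known only as a limit, the size of the step to compound 3 cannot be fixed; no step beyond the scatter in this assay is assumed. Compound 3 is therefore expected near 10000 nM, between 4000 nM and 25000 nM. The step from compound 2 to compound 3 is expected to be a number no higher from compound 2 to compound 3 (the limit leaves the size open).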

Compound 3, half-maximal inhibitory concentration: 378 nM
The estimate for compound 3 lay 26-fold (1.42 log units) above the measured number, and the stated range ends above it.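

In this assay, the group on the aromatic carbon next to the ring nitrogen clearly governs the read-out: (3,3,3-trifluoropropyl)amino in place of cyclopropyl gives an at least 26-fold lower number from compound 2 to compound 3 (1.42 log units; beyond the scatter). This single change takes the series from a limit to a measured number, so the step has a bound and not an exact size: the limit of > 10000 nM in this assay, at which 1 of the 3 values shown sits.

Still open, from the compounds shown here alone, is whether the step belongs to the amine nitrogen or to the fluorinated chain. A plain propylamino group, a morpholine or a longer trifluoroalkyl amine at this carbon would separate the two.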